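The source may report more compounds than this note shows. Statements on the series, on what has been measured and on what is new or still open speak of the compounds shown alone.

Measured so far in a functional assay on PC-3 cells (Homo sapiens) for inhibition, read by sulforhodamine B assay, with a stated time of 72 h; a lower number here means a stronger inhibitor, a higher number a weaker inhibitor:
- compound 1 `CC1CN(C(=O)c2c(N)sc(-c3ccc(Cl)cc3)c2-c2ccc(Cl)cc2)CCN1`: 7210 nM
- compound 2 `CCOC(=O)Nc1sc(-c2ccc(Cl)cc2)c(-c2ccc(Cl)cc2)c1C(=O)NC1CC1`: 27600 nM
- compound 3 `Nc1sc(-c2ccc(Cl)cc2)c(-c2ccc(Cl)cc2)c1C(=O)NC1CCC(O)CC1`: 5670 nM

Compound 3, at 5670 nM, is level with compound 1 within the scatter, and compound 2 shows a clearly higher number at 27600 nM. The next compound, compound 4 `Nc1sc(-c2ccc(Cl)cc2)c(-c2ccc(Cl)cc2)c1C(=O)N1CCCC1`, has pyrrolidin-1-yl in place of (4-hydroxycyclohexyl)amino on a carbonyl carbon.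

Among the compounds with values here, only one measured step bears directly on this place. Exchanging 3-methylpiperazin-1-yl for (4-hydroxycyclohexyl)amino gave a 1.3-fold lower number from compound 1 to compound 3 (0.10 log units; within the scatter), so that replacement left the reading in this assay essentially unmoved. Compound 2 differs from compound 3 in more than one place, so it gives no clean reading of this position. A single step is thin evidence, and pyrrolidin-1-yl itself has not been measured in this series. Even so, the step from compound 1 offers no reason to expect a large shift, and no change beyond the scatter is anticipated in this assay, in either direction. The expected result is a 1.1-fold higher number from compound 3 to compound 4 (0.06 log units; within the scatter), an estimate that stays within the scatter. For compound 4 the estimated value is 6500 nM, with an expected range of 2800 nM to 15000 nM.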

Compound 4, half-maximal inhibitory concentration: 6220 nM
Beside the measured number, compound 4's estimate is 1.0-fold (0.02 log units) above it, and the stated range covers the measured number.
By their numbers in this assay, from the lowest: compounds 3, 4 and 1 (each within the scatter of the next); then compound 2.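

In this assay, pyrrolidin-1-yl in place of (4-hydroxycyclohexyl)amino on a carbonyl carbon gave a 1.1-fold higher number from compound 3 to compound 4 (0.04 log units; within the scatter), and pyrrolidin-1-yl in place of 3-methylpiperazin-1-yl gave a 1.2-fold lower number from compound 1 to compound 4 (0.06 log units; within the scatter), so the three groups in compound 1, compound 3 and compound 4 now read alike within the scatter. The earlier step compared only the first two. This new one shows that the reading in this assay also holds with a group of fewer heavy atoms and with 0 hydrogen-bond donors and 0 hydrogen-bond acceptors, where the group it replaces has both, so across these three compounds neither that count nor the ring type separates the numbers. Nothing available explains why the number stays put at this position.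

From the compounds shown here alone, whether this tolerance extends to a carboxylic acid, a phenyl ring or a longer chain carrying an amine on the same carbonyl carbon remains open. Compound 2, at 27600 nM, differs from these compounds in more than one place, so the separate contributions of its ethyl carbamate and its cyclopropylamino group also remain unresolved.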